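Trimming the Side Chain of Compound 2

The compounds below may be only part of what the source reports. "The series", "measured", "known", "first", "only" and "open" are said of these compounds alone.

In a functional assay on HT-29 cells (Homo sapiens) for inhibition (a lower number here means a stronger inhibitor, a higher number a weaker inhibitor), compound 1 `COc1c(C)cnc(CN2CC(=O)N(CC(C)C)c3c(Cl)nc(N)nc32)c1C` gives 40 nM and compound 2 `COc1c(C)cnc(CN2c3nc(N)nc(Cl)c3NC(=O)[C@@H]2CC(C)C)c1C` gives 690 nM as the higher of the two numbers, which makes compound 2 the weaker inhibitor by a gap beyond the scatter. Compound 3 `COc1c(C)cnc(CN2c3nc(N)nc(Cl)c3NC(=O)[C@@H]2C)c1C` differs from compound 2 by hydrogen in place of isopropyl on a saturated chain carbon bound to a saturated ring carbon in one place, with hydrogen in place of isopropyl on a saturated chain carbon bound to a saturated ring carbon, so isobutyl becomes methyl. Among the compounds with values here, no measured step covers this change, so any forecast is tentative. A modest move toward a lower number is expected, an estimated 2.3-fold lower number from compound 2 to compound 3 (0.36 log units; beyond the scatter) that may not clear the scatter. Compound 3 is expected in this assay at 300 nM with 60 nM to 1500 nM as the likely range.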

Compound 3, half-maximal inhibitory concentration: 660 nM
Estimate against measurement, compound 3: 2.2-fold (0.34 log units) below, within the range that was stated.
By their numbers in this assay, from the lowest: compound 1; then compounds 3 and 2 (each within the scatter of the next).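

In this assay, trimming isobutyl to methyl on this saturated ring carbon gives a 1.0-fold lower number from compound 2 to compound 3 (0.02 log units; within the scatter) and so no measurable shift in the read-out. Until now this position had been seen with isobutyl alone, and it now holds two chain sizes with matching numbers, so the isopropyl part of the chain makes no visible difference here. No supporting data bear on why these numbers match.

Still open, on these data alone, is whether a longer chain, an amine or a carboxylic acid on this carbon would also leave the number unchanged.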